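The source may hold more compounds than are shown below. What is called first, only, known or untested is meant among the compounds shown, and "the series" means these compounds.

Compound 1 `Cc1ccc(-n2cc(CNC(=O)c3cccc4c3cnn4C(C)C)nn2)c(C)c1` is the reference point of this set. In a functional assay on MGC-803 cells (Homo sapiens) for inhibition, read by MTT assay, with a stated time of 72 h (on this read-out higher numbers stand for weaker inhibition and lower numbers for stronger inhibition), compound 1 gives > 40000 nM, which is a limit of the assay and not a number. Compound 2 `CC(C)n1ncc2c(C(=O)NCc3cn(-c4ccc(I)cc4)nn3)cccc21` carries 4-iodophenyl on the aromatic nitrogen; in this assay compound 2 gives > 40000 nM, again a limit. Compound 3 `Cc1ccccc1-n1cc(CNC(=O)c2cccc3c2cnn3C(C)C)nn1` has hydrogen in place of methyl on an aromatic carbon; in this assay compound 3 gives > 40000 nM, also a limit. All three measured values thus rest at the limit of > 40000 nM in this assay, at which 3 of the 3 values shown sit, so the steps a step that the two limits leave unreadable from compound 1 to compound 2, a step that the two limits leave unreadable from compound 1 to compound 3 and a step that the two limits leave unreadable from compound 2 to compound 3 cannot be read in size or direction.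

Compound 4 `CC(C)n1ncc2c(C(=O)NCc3cn(-c4ccc(C(F)(F)F)cc4)nn3)cccc21` differs from compound 1 by 4-(trifluoromethyl)phenyl in place of 2,4-dimethylphenyl on an aromatic nitrogen. The change sits on an aromatic nitrogen of a five-membered aromatic ring with 3 nitrogen. The measured steps that bear on it are those that also vary the group on that nitrogen, a step that the two limits leave unreadable from compound 1 to compound 2 and a step that the two limits leave unreadable from compound 2 to compound 3, and both are unreadable because every value sits at the limit of > 40000 nM in this assay, at which 3 of the 3 values shown sit. The numbers give no readable step for any change of this group, so for this assay no step beyond the scatter can be expected in either direction, and compound 4 is expected most likely to sit at the limit as well. For compound 4 the estimate in this assay is 60000 nM, within 20000 nM to 200000 nM. The step that the limit leaves unreadable from compound 1 to compound 4 is accordingly expected to be none beyond the scatter.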

Compound 4, half-maximal inhibitory concentration: > 40000 nM
Compound 4 was reported as a limit; the forecaster's own chance of this, stated with the estimate: 85%; the middle value does not contradict the limit.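

In this assay compound 4 gives > 40000 nM, a limit of the assay and not a number. The steps linking compound 4 to compounds 1, 2 and 3 cannot be read in size or direction: the limit of > 40000 nM in this assay, at which 4 of the 4 values shown sit. The compounds shown leave open whether any group on the aromatic nitrogen gives a measurable value in this assay.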